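Fluoropurine Benzyl Analogues: Oxolanyl Replaced by Allyl

This account rests on a few compounds, and the source may have more. Where it says the series, first, only, none or still open, it means among the compounds named here.

Compound 1 `COc1cc(Cc2nc3c(N)nc(F)nc3n2CC2CCCO2)cc(OC)c1OC`: 22900 nM
Compound 2 `COc1cc(Cc2nc3c(N)ncnc3n2CC(C)C)cc(OC)c1OC`: 97700 nM

In a functional assay on MCF7 cells (Homo sapiens) for antiproliferative activity (a lower number here means a stronger inhibitor, a higher number a weaker inhibitor), compound 1 gives 22900 nM, the lower of the two numbers. Compound 2 gives 97700 nM in this assay, a weaker result that lies beyond the scatter, though the two structures differ in more than one place. Compound 3 `C=CCCn1c(Cc2cc(OC)c(OC)c(OC)c2)nc2c(N)nc(F)nc21` has not been measured; it differs from compound 1 by allyl in place of oxolan-2-yl on a saturated chain carbon bound to an aromatic nitrogen. Going by the values given here, no step between measured compounds isolates this change, so the expected step from compound 1 to compound 3, a 1.5-fold higher number from compound 1 to compound 3 (0.18 log units; within the scatter), is a modest weakening estimated with wide uncertainty. Compound 3 is therefore expected to give about 35000 nM, within 12000 nM to 100000 nM.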

Compound 3, half-maximal inhibitory concentration: 33100 nM
Beside the measured number, compound 3's estimate is 1.1-fold (0.02 log units) above it; low and high end bracket the measured number.
By their numbers in this assay, from the lowest: compounds 1 and 3 (each within the scatter of the next); then compound 2.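

In this assay, going by these compounds alone, the exchange of oxolan-2-yl for allyl on a saturated chain carbon bound to an aromatic nitrogen gives a 1.4-fold higher number from compound 1 to compound 3 (0.16 log units; within the scatter) and is the first comparison at this position that differs in one place only. Removing the ring and its hydrogen-bond acceptor therefore does not separate the two compounds beyond the scatter. No measurement at hand gives a reason for this. From the compounds shown here alone, whether an amine, a carboxylic acid or a longer chain at this position would shift the number beyond the scatter remains open.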